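This account rests on a few compounds, and the source may have more. Where it says the series, first, only, none or still open, it means among the compounds named here.

Measured compounds:
- compound 1, `CCC1C(=O)N(C)c2cnc(Nc3ccc(S(N)(=O)=O)cc3)nc2N1C`: in an assay on Sf9 cells for inhibition of serine/threonine-protein kinase 4 (Homo sapiens), read by luminescence and ADP-Glo, with a stated time of 1 h, in the presence of a further agent that is not named here (a higher number here means a weaker inhibitor, a lower number a stronger inhibitor), compound 1 gives 479 nM
- compound 2, `CN1C(=O)C(c2ccc(F)cc2)N(C)c2nc(Nc3ccc(S(N)(=O)=O)cc3)ncc21`: in this assay compound 2 gives 1770 nM
- compound 3, `CN1C(=O)C(c2cccc(Cl)c2)N(C)c2nc(Nc3ccc(S(N)(=O)=O)cc3)ncc21`: in this assay compound 3 gives 989 nM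

Compound 3 stands second highest of the three numbers in this assay. Its nearest neighbour is compound 2, and that gap is within the scatter (a 1.8-fold lower number from compound 2 to compound 3 (0.25 log units; within the scatter)); the gap to compound 1 is beyond the scatter (a 2.1-fold higher number from compound 1 to compound 3 (0.31 log units; beyond the scatter)).

Compound 4, `CCc1ccccc1C1C(=O)N(C)c2cnc(Nc3ccc(S(N)(=O)=O)cc3)nc2N1C`, differs from compound 3 in one place: 2-ethylphenyl in place of 3-chlorophenyl on a saturated ring carbon.

Two measured steps exchange the ethyl of compound 1 for an aryl group on the same saturated ring carbon, a 3.7-fold higher number from compound 1 to compound 2 (0.57 log units; beyond the scatter) and a 2.1-fold higher number from compound 1 to compound 3 (0.31 log units; beyond the scatter), both modest and both toward a higher number. Among the measured compounds shown here, the one aryl-for-aryl exchange in the set, a 1.8-fold lower number from compound 2 to compound 3 (0.25 log units; within the scatter), stays within the scatter. The move to compound 4 is again an aryl-for-aryl exchange on that carbon, so no step beyond the scatter is expected in this assay; the number is expected to remain near those of compound 2 and compound 3 rather than return toward compound 1.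

Compound 4 is therefore estimated at 1100 nM, with an expected range of 450 nM to 2700 nM. The step this estimate implies, a 1.1-fold higher number from compound 3 to compound 4 (0.05 log units; within the scatter), is expected to lie within the scatter.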

Compound 4, half-maximal inhibitory concentration: 51 nM
The estimate for compound 4 lay 22-fold (1.33 log units) above the measured number, outside the stated range (below it).
By their numbers in this assay, from the lowest: compound 4; then compound 1; then compounds 3 and 2 (each within the scatter of the next).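

In this assay, among the compounds shown here, the aryl group on the saturated ring carbon is not a interchangeable placeholder: 2-ethylphenyl gives a 19-fold lower number from compound 3 to compound 4 (1.29 log units; beyond the scatter) and a 35-fold lower number from compound 2 to compound 4 (1.54 log units; beyond the scatter), both large, whereas the only earlier aryl-for-aryl exchange, a 1.8-fold lower number from compound 2 to compound 3 (0.25 log units; within the scatter), stayed within the scatter. An aryl group at this position also no longer goes only with a higher number than ethyl: a 9.4-fold lower number from compound 1 to compound 4 (0.97 log units; beyond the scatter) runs opposite to a 3.7-fold higher number from compound 1 to compound 2 (0.57 log units; beyond the scatter) and a 2.1-fold higher number from compound 1 to compound 3 (0.31 log units; beyond the scatter), so compound 2 and compound 3 go against any reading of compound 4 as a general aryl effect, and this carbon tolerates at least one aryl group with a lower number than ethyl. No measurement shown here bears on why 2-ethylphenyl differs so sharply from the other two aryl groups.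

The compounds shown leave open whether the lower number of compound 4 belongs to the ethyl group itself or to where it sits on the phenyl ring, and a phenyl ring with no substituent would be the plain reference for both questions. They also leave open how far the step holds if a methyl, a propyl chain or a chlorine takes the place of the ethyl of 2-ethylphenyl.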